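The source may report more compounds than this note shows. Statements on the series, on what has been measured and on what is new or still open speak of the compounds shown alone.

In a functional assay for agonist activity at G protein-coupled receptor 88 (Homo sapiens), read by HTRF and cAMP accumulation (on this read-out lower numbers stand for an effect already at smaller amounts and higher numbers for an effect only at larger amounts of compound), three compounds have been measured so far. Compound 1 `CC(C)C[C@H](N)CN(C(=O)C(C)Cc1ccccc1)c1ccc(-c2ccccc2)cc1` gives 1.2 nM, compound 2 `CC(C)C[C@H](N)CN(C(=O)[C@@H]1C[C@H]1c1ccccc1)c1ccc(-c2ccc(F)cc2)cc1` gives 900 nM, and compound 3 `CC[C@H](C)[C@H](N)CN(C(=O)[C@@H]1C[C@H]1c1ccccc1)c1ccc(-c2ccc(OC(C)C)cc2)cc1` gives 72 nM. Among these three, compound 3 holds the second highest number: it stands nearer to compound 2 than to compound 1, yet both of its gaps lie beyond the usual scatter, so compound 3 acts at smaller amounts than compound 2 and at larger amounts than compound 1.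

Compound 4 `CC[C@H](C)[C@H](N)CN(C(=O)[C@@H]1C[C@H]1c1ccccc1)c1ccc(-c2ccc(CNC)cc2)cc1` has not yet been measured. It differs from compound 3 in one place: (methylamino)methyl in place of isopropoxy on an aromatic carbon. Going by the values given here, no pair of measured compounds shows this exchange, so there is no measured step to lean on, and the three values give no direct guide to what the new group does. The expectation for the step of a 2.1-fold higher number from compound 3 to compound 4 (0.32 log units; beyond the scatter) is therefore a modest shift toward a higher number, not far beyond the scatter. In this assay compound 4 is expected to give about 150 nM, within a range from 40 nM to 600 nM.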

Compound 4, half-maximal effective concentration: 6400 nM
Beside the measured number, compound 4's estimate is 43-fold (1.63 log units) below it; the measured number lies above the stated range.
By their numbers in this assay, from the lowest: compound 1; then compound 3; then compound 2; then compound 4.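

In this assay, this aromatic carbon, para to a large group, proves highly sensitive to what it carries: (methylamino)methyl in place of isopropoxy gives an 89-fold higher number from compound 3 to compound 4 (1.95 log units; beyond the scatter). The two groups are both open chains without a ring, yet the entering one carries a nitrogen and a hydrogen-bond donor where the leaving one has an oxygen and no donor, so this position does not treat such chains alike. Nothing measured here explains why the number rises so sharply.

On these data alone, it remains open which difference between the two groups goes with the step, and a (dimethylamino)methyl or a methoxy group at this position would help to separate them. As far as these compounds go, whether the same exchange would have a similar effect on the core of compound 1 also remains open.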